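The compounds below may be only part of what the source reports. "The series", "measured", "known", "first", "only" and "open" are said of these compounds alone.

In a functional assay on PC-3 cells (Homo sapiens) for cytotoxicity (a higher number here means a weaker inhibitor, a lower number a stronger inhibitor), compound 1 `COc1ccc2c(c1)c(/C=N\NC(=O)c1c[nH]c3ccc(Br)cc13)cn2Cc1ccc(Cl)cc1` gives 15900 nM, while compound 2 `COc1ccc2c(c1)c(/C=N\NC(=O)c1c[nH]c3ccccc13)cn2Cc1ccc(Cl)cc1` gives 30300 nM. Within the data shown here, the step of a 1.9-fold higher number from compound 1 to compound 2 (0.28 log units; within the scatter) keeps these two within the scatter, so compound 2 stands level with the only other number measured. Compound 3 `O=C(N/N=C\c1cn(Cc2ccc(Cl)cc2)c2ccc(Br)cc12)c1c[nH]c2ccccc12` differs from compound 2 by bromo in place of methoxy on an aromatic carbon. Among the measured compounds shown here, the single measured step, a 1.9-fold higher number from compound 1 to compound 2 (0.28 log units; within the scatter), concerned bromo against hydrogen rather than bromo against methoxy, and it stayed within the scatter, so no step beyond the scatter is expected in this assay. Compound 3 is therefore estimated at 25000 nM, with a range from 8000 nM to 80000 nM. This expectation amounts to a 1.2-fold lower number from compound 2 to compound 3 (0.08 log units; within the scatter).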

Compound 3, half-maximal inhibitory concentration: 12400 nM
Beside the measured number, compound 3's estimate is 2.0-fold (0.30 log units) above it; the range from low to high includes it.
By their numbers in this assay, from the lowest: compounds 3, 1 and 2 (each within the scatter of the next, the first and the last beyond it).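

In this assay the change from methoxy to bromo gives a 2.4-fold lower number from compound 2 to compound 3 (0.39 log units; beyond the scatter) and is the only step shown that lies beyond the scatter, though it is modest. The other step, a 1.9-fold higher number from compound 1 to compound 2 (0.28 log units; within the scatter), lay at a different place and stayed within the scatter, so this position on the six-membered aromatic ring of carbon only is where a single change first moves the number. Nothing available accounts for the difference between methoxy and bromo here. The compounds shown leave open how an amine or a carboxylic acid at this position would compare with bromo. They also leave open whether bromo at this position and bromo at the place it occupies in compound 1 would combine.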